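This account rests on a few compounds, and the source may have more. Where it says the series, first, only, none or still open, it means among the compounds named here.

Compound 1 `COc1cc(CNC(=O)CCCCCCC(C)C)ccc1OC(=O)c1ccc(C(N)=S)cc1`: > 50000 nM.
Compound 2 `COc1cc(CNC(=O)CCCC/C=C/C(C)C)ccc1OC(=O)c1ccc(C(N)=S)cc1`: 39600 nM.
Compound 3 `COc1cc(CNC(=O)CCCC/C=C/C(C)C)ccc1OC(=O)CCC(=O)Oc1ccc(C(N)=S)cc1`: > 50000 nM.

In a functional assay on HeLa cells (Homo sapiens) for antiproliferative activity, read by MTT assay, with a stated time of 48 h (a higher number here means a weaker inhibitor, a lower number a stronger inhibitor), compound 2 gives 39600 nM. For compound 1 the value > 50000 nM is a limit of the assay, not a number. For compound 3 the value > 50000 nM is also a limit of the assay. The difference between the cores of compound 2 and compound 3 is not broken down here.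

Compound 1 differs from compound 2 by one change, (isopentyl in place of 3-methylbut-1-en-1-yl on a saturated chain carbon, four bonds along the chain from a carbonyl carbon), and that change gave an at least 1.2-fold higher number from compound 2 to compound 1 (0.10 log units; that floor lies within the scatter). The unmeasured compound 4 `COc1cc(CNC(=O)CCCCCCC(C)C)ccc1OC(=O)CCC(=O)Oc1ccc(C(N)=S)cc1` differs from compound 3 by the same change, (isopentyl in place of 3-methylbut-1-en-1-yl on a saturated chain carbon, four bonds along the chain from a carbonyl carbon), at the same place.

Compound 3 already sits at the limit of > 50000 nM in this assay, at which 2 of the 3 values shown sit, so the same change starting from compound 3 can only be expected to leave compound 4 at or beyond that limit. This expectation rests on the measured step of an at least 1.2-fold higher number from compound 2 to compound 1 (0.10 log units; that floor lies within the scatter). The expected step is a step that the limit leaves unreadable from compound 3 to compound 4. Compound 4 is therefore expected to give about 80000 nM in this assay, most likely reported only as a limit, with a range from 50000 nM to 200000 nM.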

Compound 4, half-maximal inhibitory concentration: > 50000 nM
Compound 4: only a limit was reported; the forecaster's own chance of this, stated with the estimate: 90%; the middle value lies beyond the limit too.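

In this assay, compound 3 and compound 4 both stop at the same limit, so no step can be read between them: the limit of > 50000 nM in this assay, at which 3 of the 4 values shown sit.

The compounds shown leave open how far beyond that limit each of the two lies, and whether isopentyl in place of 3-methylbut-1-en-1-yl changes anything on the core of compound 3.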